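Moving the Fluorine on a Fluorophenyl Group

A few compounds are considered here, and "the series" means these few. Any claim that something is new, unique, unknown or untested is made for them only; others in the source may bear on it.

In an ADME assay on HEp-2 cells (Homo sapiens) for cytotoxicity, read by trypan blue exclusion, with a stated time of 24 h (a lower number here means that less compound is tolerated, a higher number that more compound is tolerated), compound 1 (`C/C(=N\N=C1/SCC(=O)N1Cc1cccc(F)c1)c1cccs1`) gives 6 ug/mL. Compound 2 (`C/C(=N/N=C1\SCC(=O)N1Cc1ccc(F)cc1)c1cccs1`) gives 15 ug/mL. Compound 1 therefore holds the lower of the two numbers, and the gap between them lies beyond the usual scatter of repeated measurements. Compound 3 (`C/C(=N\N=C1/SCC(=O)N1Cc1ccccc1F)c1cccs1`) has not yet been measured. It differs from compound 1 in one place: 2-fluorophenyl in place of 3-fluorophenyl on a saturated chain carbon bound to an amide-type nitrogen in a ring. The change puts 2-fluorophenyl in place of 3-fluorophenyl on a saturated chain carbon bound to an amide-type nitrogen in a ring. Among the compounds with values here, no measured pair shows this kind of change on its own, so the expectation rests on very little. A step within the scatter in this assay, with no firm direction, is expected, and the estimate is a 1.3-fold higher number from compound 1 to compound 3 (0.12 log units; within the scatter). For compound 3, the expected value is 8 ug/mL, with an estimated range from 3 ug/mL to 20 ug/mL.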

Compound 3, half-maximal cytotoxic concentration in the HEp-2 assay: 15 ug/mL
Estimate against measurement, compound 3: 1.9-fold (0.27 log units) below, within the range that was stated.
By their numbers in the HEp-2 assay, from the lowest: compound 1; then compounds 2 and 3 (each within the scatter of the next).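

In the HEp-2 assay, 2-fluorophenyl in place of 3-fluorophenyl gives a 2.5-fold higher number from compound 1 to compound 3 (0.40 log units; beyond the scatter). This position on the saturated chain carbon therefore responds to where the fluorine sits on the phenyl ring, even though the two groups hold the same atoms, and more compound is tolerated with 2-fluorophenyl in this one pair. In a physicochemical assay, with a stated time of 30 min (a lower number here means a stronger inhibitor, a higher number a weaker inhibitor), compound 1 gives > 5000000 nM, which is a limit of the assay and not a number.

In the physicochemical assay compound 3 gives > 5000000 nM, also a limit, so the step there cannot be read: the limit of > 5000000 nM in the physicochemical assay, at which 2 of the 2 values shown sit. Whether an amine or a carboxylic acid in place of the fluorine, or a longer chain in place of the saturated chain carbon, would shift the number in the HEp-2 assay stays open, as does the reason for the step.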